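Methoxy to nitro on the aromatic ring of compound 3

The source may report more compounds than this note shows. Statements on the series, on what has been measured and on what is new or still open speak of the compounds shown alone.

Compound 3 `COc1ccc(/C(C)=N/NC(=S)NC(C)(C)[C@H]2CC=C(C)CC2)cc1` is the only one of the three measured compounds to give a number in a functional assay on PC-3 cells (Homo sapiens) for inhibition, read by sulforhodamine B assay, with a stated time of 48 h (a higher number here means a weaker inhibitor of growth, a lower number a stronger inhibitor of growth), where compound 3 gives 83600 nM. Compound 1 `CC1=CC[C@H](C(C)(C)NC(=S)N/N=C/c2ccc(N(C)C)cc2)CC1` reaches only a limit of this assay, < 40 nM. Compound 2 `CC1=CC[C@H](C(C)(C)NC(=S)N/N=C(\C)c2ccccc2)CC1` likewise reaches only a limit of this assay, > 100000 nM. Among the compounds with values here, the single measured step puts methoxy in place of hydrogen on an aromatic carbon and gives an at least 1.1-fold lower number from compound 2 to compound 3 (0.07 log units; that floor lies within the scatter), a change within the scatter. Compound 4 `CC1=CC[C@H](C(C)(C)NC(=S)N/N=C(\C)c2ccc([N+](=O)[O-])cc2)CC1` differs from compound 3 by nitro in place of methoxy on an aromatic carbon. Within the data shown here, no measured step exchanges one such group for another; the only guide is that step on an aromatic carbon, which stayed within the scatter, so no change beyond the scatter is expected. Compound 4 is therefore estimated at 80000 nM, with a range from 20000 nM to 300000 nM. The step this estimate implies, a 1.0-fold lower number from compound 3 to compound 4 (0.02 log units; within the scatter), is expected to lie within the scatter.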

Compound 4, concentration for 50% growth inhibition: 62600 nM
For compound 4 the middle estimate is 1.3-fold (0.11 log units) above the measured one; measured number inside the range.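

In this assay, within the data shown here, nitro in place of methoxy on this aromatic carbon, para to a large group, gives a 1.3-fold lower number from compound 3 to compound 4 (0.13 log units; within the scatter) and so shows the first exchange of one group for another here, with the two groups not told apart. Nitro in place of hydrogen gives an at least 1.5-fold lower number from compound 2 to compound 4 (0.20 log units; that floor lies within the scatter) as a floor only, so the full size of that step stays unknown. Nothing in the data at hand explains why these groups behave alike. From the compounds shown here alone, whether an amine or a carboxylic acid on this same carbon would move the number beyond the scatter remains open.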